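A few compounds are considered here, and "the series" means these few. Any claim that something is new, unique, unknown or untested is made for them only; others in the source may bear on it.

Among the compounds with values here, in a functional assay on VCaP cells (Homo sapiens) for antiproliferative activity, read by propidium iodide staining, with a stated time of 96 h (on this read-out lower numbers stand for stronger inhibition and higher numbers for weaker inhibition), three compounds built on one shared core have numbers so far. Compound 1 (`CC(O)(CSc1ccc(S(F)(F)(F)(F)F)cc1)C(=O)Nc1ccc(S(F)(F)(F)(F)F)cc1`) gives 28000 nM and compound 2 (`CC(O)(CSc1cccc(S(F)(F)(F)(F)F)c1)C(=O)Nc1ccc(S(F)(F)(F)(F)F)cc1`) gives 28200 nM in the same test. Compound 3 (`CC(O)(CSc1ccc(F)cc1)C(=O)Nc1ccc(S(F)(F)(F)(F)F)cc1`) gives 23000 nM and stands level with both of them, as all three numbers lie within the usual scatter of one another.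

Compound 4 (`CC(O)(CSc1cccc(C(F)(F)F)c1)C(=O)Nc1ccc(S(F)(F)(F)(F)F)cc1`) has not yet been measured. It has 3-(trifluoromethyl)phenyl in place of 4-fluorophenyl on a sulfur and keeps the rest of compound 3 unchanged.

Within the data shown here, one measured step bears on this exchange, since it also alters the aromatic group on the sulfur: a 1.2-fold lower number from compound 1 to compound 3 (0.09 log units; within the scatter) is all that this change of group produced, and it stays within the scatter. Among the measured compounds shown here, no measured compound carries the 3-(trifluoromethyl)phenyl group, so the data offer no direct precedent for it. For the measured compounds named here, the numbers so far show no change at this place that goes beyond the scatter, and none beyond the scatter is expected here. The expected step is a 1.1-fold higher number from compound 3 to compound 4 (0.04 log units; within the scatter) in this assay on this reasoning. Compound 4 is estimated at 25000 nM with 12000 nM to 45000 nM as its expected range.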

Compound 4, half-maximal inhibitory concentration: 18800 nM
The estimate for compound 4 lay 1.3-fold (0.12 log units) above the measured number, and the stated range covers the measured number.
By their numbers in this assay, from the lowest: compounds 4, 3, 1 and 2 (each within the scatter of the next).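

In this assay the exchange of 4-fluorophenyl for 3-(trifluoromethyl)phenyl on the sulfur gives a 1.2-fold lower number from compound 3 to compound 4 (0.09 log units; within the scatter) and so brings no change beyond the scatter, even though the entering group has more heavy atoms and carries a trifluoromethyl group rather than a single fluorine. The comparison of the trifluoromethyl group with the group of five fluorines on sulfur, made on an aromatic carbon, gives a 1.5-fold lower number from compound 2 to compound 4 (0.18 log units; within the scatter) and adds a second exchange that stays within the scatter, so these two groups are not told apart in this read-out. The aromatic group on the sulfur has now been varied in several ways, and every step among these compounds remains within the scatter, which means that the numbers show no preference among the groups tried here.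

All of these compounds keep an aromatic ring carrying fluorine on the sulfur, so it remains open whether an amine, a carboxylic acid or a longer chain in that place would move the number beyond the scatter. The same holds for any change to the group on the amide nitrogen, which stays the same throughout. No measurement is available that would account for these numbers.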